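This account rests on a few compounds, and the source may have more. Where it says the series, first, only, none or still open, it means among the compounds named here.

In a functional assay on A549 cells (Homo sapiens) for antiproliferative activity, read by MTT assay, with a stated time of 72 h (a lower number here means a stronger inhibitor, a higher number a weaker inhibitor), three compounds have been measured, and their values sit close together. Compound 1 `O=C1COc2ccc(-c3cnc(Cl)c(NS(=O)(=O)c4ccc(F)cc4)c3)cc2N1C1CCCCC1` gives 37900 nM, compound 2 `O=C1COc2ccc(-c3cccc(NS(=O)(=O)c4ccc(F)cc4)c3)cc2N1` gives 32100 nM, and compound 3 `COc1ccc(N2C(=O)COc3ccc(-c4cnc(Cl)c(NS(=O)(=O)c5ccc(F)cc5)c4)cc32)cc1` gives 30400 nM. Compound 3 lies within the scatter of both others, so its place among them carries no ranking.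

The next structure is compound 4 `O=C1COc2ccc(-c3cnc(Cl)c(NS(=O)(=O)c4ccc(F)cc4)c3)cc2N1`, which has hydrogen in place of 4-methoxyphenyl on an amide-type nitrogen in a ring. Among the compounds with values here, only one measured step changes the group on that nitrogen while the rest of the molecule stays the same. This is a 1.2-fold lower number from compound 1 to compound 3 (0.10 log units; within the scatter), with 4-methoxyphenyl in place of cyclohexyl, and it stays within the scatter. Compound 2 also carries hydrogen on that nitrogen, and its value of 32100 nM is in the same range, but its core differs from that of compound 4. Within the data shown here, no measured pair shows the group on that nitrogen replaced by hydrogen on an unchanged core, so the evidence is indirect and the range must stay wide. On this basis, no change beyond the scatter is expected in this assay, and no direction is firmly indicated. The expected change is a 1.2-fold lower number from compound 3 to compound 4 (0.08 log units; within the scatter). For compound 4 the estimated value is 25000 nM, with an expected range from 8000 nM to 60000 nM.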

Compound 4, half-maximal inhibitory concentration: > 40000 nM
Compound 4: a limit, no number (the forecaster's own chance of this, stated with the estimate: 12%); at least 1.6-fold (0.20 log units) between middle value and limit.
By their numbers in this assay, from the lowest: compounds 3, 2 and 1 (each within the scatter of the next). At a limit, above all of these: compound 4.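

In this assay compound 4 gives only a limit and not a number, > 40000 nM, and it is the one compound in the series that does: the limit of > 40000 nM in this assay, at which 1 of the 4 values shown sits.

On the shared core, replacing either ring group on the amide-type nitrogen with hydrogen can now be read in two steps, an at least 1.3-fold higher number from compound 3 to compound 4 (0.11 log units; that floor lies within the scatter) and an at least 1.0-fold higher number from compound 1 to compound 4 (0.02 log units; that floor lies within the scatter). Within the data shown here, this is the first look at this position with no ring group on it, and it shows that the bare nitrogen brings no lower number, although both floors lie within the scatter and so do not establish any loss from removing the 4-methoxyphenyl or the cyclohexyl.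

On these data alone, the true value of compound 4 remains unknown, so the real size of both steps stays open, and a ring group on this nitrogen cannot yet be said to matter in this assay. The compounds shown also leave open how a methyl, or a longer chain ending in an amine or a carboxylic acid, would read at this nitrogen on the same core.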